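From iodomethyl to hydroxymethyl on the shared core

This account rests on a few compounds, and the source may have more. Where it says the series, first, only, none or still open, it means among the compounds named here.

Among the compounds with values here, in a functional assay on A-431 cells (Homo sapiens) for antiproliferative activity, read by sulforhodamine B assay, with a stated time of 72 h (on this read-out lower numbers stand for stronger inhibition and higher numbers for weaker inhibition), compound 2 (`C=C1CC(CI)(c2ccccc2)OC1=O`) gives 2720 nM and so holds the lower of the only two numbers available. Compound 1 (`C=C1CC(CF)(c2ccccc2)OC1=O`) gives 25100 nM in this assay as well. Compound 3 (`C=C1CC(CO)(c2ccccc2)OC1=O`) has not yet been measured. It carries hydroxy in place of iodo on a saturated chain carbon bound to a saturated ring carbon, the iodomethyl to hydroxymethyl change. Within the data shown here, one measured step bears on it, at the same place: iodo in place of fluoro gave a 9.2-fold lower number from compound 1 to compound 2 (0.97 log units; beyond the scatter) and counts as modest, though beyond the scatter. Among the measured compounds shown here, no hydroxy compound has been measured, so the size of the next step remains uncertain. For the measured compounds named here, compound 2 is the only compound with iodo, and with the iodo gone a rise of similar modest size is expected, back toward compound 1 at 25100 nM without passing far beyond it. The expected change is a 5.5-fold higher number from compound 2 to compound 3 (0.74 log units; beyond the scatter) on this reasoning. For compound 3 the estimate is 15000 nM as the middle value, with an expected range from 5000 nM to 45000 nM in this assay once it is tested.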

Compound 3, half-maximal inhibitory concentration: 4060 nM
For compound 3 the middle estimate is 3.7-fold (0.57 log units) above the measured one, outside the stated range (below it).
By their numbers in this assay, from the lowest: compounds 2 and 3 (each within the scatter of the next); then compound 1.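

In this assay, hydroxy in place of iodo on a saturated chain carbon bound to a saturated ring carbon gives a 1.5-fold higher number from compound 2 to compound 3 (0.17 log units; within the scatter), so the iodomethyl and hydroxymethyl compounds cannot be told apart at this position. Hydroxy in place of fluoro gives a 6.2-fold lower number from compound 1 to compound 3 (0.79 log units; beyond the scatter), which shows that the step away from fluoro does not depend on iodo: among these three compounds, fluoro alone stands apart, and both of the other groups lie beyond the scatter from it. Iodo and hydroxy share this result even though the hydrogen-bond donor and acceptor counted on hydroxy are absent from iodo, so those counts do not sort the three compounds at this place. Nothing available here explains why fluoro parts from the other two groups.

The compounds shown leave open whether chloro, bromo, methoxy or an amine in the same place would fall with iodo and hydroxy or with fluoro. They also leave open whether a longer chain carrying hydroxy would keep a number close to those of compound 2 and compound 3.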